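Swapping the Amide Aryl Group: Expecting Compound 4

This account rests on a few compounds, and the source may have more. Where it says the series, first, only, none or still open, it means among the compounds named here.

Three compounds have been measured in an assay on cells for inhibition of Amine oxidase [flavin-containing] B (Homo sapiens), read by fluorescence and Amplex Red, using microsomes, with a stated time of 15 min; on this read-out lower numbers stand for stronger inhibition and higher numbers for weaker inhibition:
Compound 1, `Cc1ccc2oc(=O)c(C(=O)Nc3ccccc3)cc2c1`, gives 15.3 nM.
Compound 2, `Cc1ccc2occ(C(=O)Nc3cccc(Cl)c3)c(=O)c2c1`, gives 4.2 nM.
Compound 3, `Cc1ccc2oc(=O)c(C(=O)Nc3ccc(Cl)cc3)cc2c1`, gives 11.1 nM.

Compound 2 gives the lowest of the three numbers; its nearest neighbour is compound 3 and its furthest is compound 1, and both gaps lie beyond the usual scatter. Compound 4, `Cc1ccc2occ(C(=O)Nc3ccc(O)cc3)c(=O)c2c1`, is not yet measured. It differs from compound 2 by 4-hydroxyphenyl in place of 3-chlorophenyl on an amide-type nitrogen. For the measured compounds named here, the only single-point step measured, a 1.4-fold lower number from compound 1 to compound 3 (0.14 log units; within the scatter), concerns a chloro on a different core and lies within the scatter, so it offers no direct guide, and no measured step touches a hydroxyl. Compound 4 is nevertheless expected to give a somewhat higher number than compound 2. The step expected is a 4.8-fold higher number from compound 2 to compound 4 (0.68 log units; beyond the scatter). For compound 4 the estimated value in this assay is 20 nM, with a likely range from 6 nM to 70 nM.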

Compound 4, half-maximal inhibitory concentration: 513 nM
Beside the measured number, compound 4's estimate is 26-fold (1.41 log units) below it, outside the stated range (above it).
By their numbers in this assay, from the lowest: compound 2; then compounds 3 and 1 (each within the scatter of the next); then compound 4.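

The earlier compounds shown here gave no step at this amide-type nitrogen on the core of compound 2. Here, 4-hydroxyphenyl in place of 3-chlorophenyl gives a 120-fold higher number from compound 2 to compound 4 (2.09 log units; beyond the scatter), so inhibition is highly sensitive to this aryl group. The two groups have equal heavy-atom counts, but only 4-hydroxyphenyl carries a hydrogen-bond donor and acceptor, and nothing available explains the loss.

The group's identity and its ring position change together, so their contributions cannot be separated. As far as these compounds go, how 3-hydroxyphenyl or 4-methoxyphenyl would behave on this core remains open.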